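The compounds below may be only part of what the source reports. "The series", "measured", "known", "first", "only" and "open" are said of these compounds alone.

Compound 1 (`CC/C=C/C(=O)Nc1cccc(Oc2nc(Nc3cccc(C#N)c3)nc3c2CSCC3)c1`) - 15900 nM
Compound 2 (`C=CC(=O)Nc1cccc(Oc2nc(Nc3ccc(OC)nc3)nc3c2CSCC3)c1`) - 17200 nM

In a functional assay on MCF7 cells (Homo sapiens) for antiproliferative activity, read by MTT assay, with a stated time of 72 h (a higher number here means a weaker inhibitor, a lower number a stronger inhibitor), compound 2 gives 17200 nM, which lies within the scatter of compound 1 at 15900 nM. Compound 3 (`CC/C=C/C(=O)Nc1cccc(Oc2nc(Nc3ccc(OC)nc3)nc3c2CSCC3)c1`) follows from compound 2 by one change: but-1-en-1-yl in place of vinyl on a carbonyl carbon. Within the data shown here, no measured pair isolates this change. Compound 3 differs elsewhere from the but-1-en-1-yl-bearing compound 1, and compound 1 gives 15900 nM. The a 1.1-fold lower number from compound 2 to compound 3 (0.03 log units; within the scatter) is therefore expected to stay within the scatter, with no direction favoured. Compound 3 is estimated at 16000 nM, with an expected range of 7000 nM to 35000 nM.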

Compound 3, half-maximal inhibitory concentration: 31500 nM
Compound 3: the middle estimate sits 2.0-fold (0.29 log units) below what was measured, and the stated range covers the measured number.
By their numbers in this assay, from the lowest: compounds 1, 2 and 3 (each within the scatter of the next).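

Among these compounds, compound 3 isolates the group on the carbonyl carbon for the first time: but-1-en-1-yl in place of vinyl gives a 1.8-fold higher number from compound 2 to compound 3 (0.26 log units; within the scatter) in this assay and so does not separate the two compounds. It also isolates the group on a nitrogen on an aromatic ring, where 6-methoxypyridin-3-yl in place of 3-cyanophenyl gives a 2.0-fold higher number from compound 1 to compound 3 (0.30 log units; within the scatter) and likewise does not separate them. From the compounds shown here alone, whether a longer chain or an amine in place of but-1-en-1-yl on the carbonyl carbon would give a step beyond the scatter stays open. No evidence bearing on these results is at hand.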